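A few compounds are considered here, and "the series" means these few. Any claim that something is new, unique, unknown or untested is made for them only; others in the source may bear on it.

Working notes on the series. In an assay on HEK293 cells for inhibition of N-acylethanolamine-hydrolyzing acid amidase (Rattus norvegicus), read by LC-MS, with a stated time of 30 min (on this read-out higher numbers stand for weaker inhibition and lower numbers for stronger inhibition), compound 3 `COc1ccc(CCCCCCC(=O)N2CCCC2)cc1` gives the highest number of the three measured, at 35400 nM. Compound 1 `Cc1ccc(CCCCCCC(=O)N2CCCC2)cc1` gives 9600 nM in this assay and compound 2 `O=C(CCCCCCc1ccc(F)cc1)N1CCCC1` gives 8000 nM; the step of a 1.2-fold lower number from compound 1 to compound 2 (0.08 log units; within the scatter) lies within the scatter, so nothing separates those two. Compound 3 stands apart from both: a 3.7-fold higher number from compound 1 to compound 3 (0.57 log units; beyond the scatter) and a 4.4-fold higher number from compound 2 to compound 3 (0.65 log units; beyond the scatter), each beyond the scatter and each with methoxy entering on the aromatic carbon.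

Compound 4 `CCCc1ccc(CCCCCCC(=O)N2CCCC2)cc1` differs from compound 3 by propyl in place of methoxy on an aromatic carbon. The two steps that bear on it are the ones in which methoxy entered, both raising the number modestly; the change to compound 4 removes methoxy and puts a hydrocarbon chain there, so a lowering of about that size is expected, bringing the number back near compound 1. Among the compounds with values here, no measured pair shows what a longer chain than methyl does, so the range is kept wide. The step of a 3.9-fold lower number from compound 3 to compound 4 (0.59 log units; beyond the scatter) is expected in this assay. Compound 4 is expected to give 9000 nM, within 3000 nM to 27000 nM.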

Compound 4, half-maximal inhibitory concentration: > 100000 nM
Compound 4 was reported as a limit (the forecaster's own chance of this, stated with the estimate: 5%); at least 11-fold (1.04 log units) between middle value and limit.
By their numbers in this assay, from the lowest: compounds 2 and 1 (each within the scatter of the next); then compound 3. At a limit, above all of these: compound 4.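

In this assay the reading of compound 4 is a limit of the assay and not a number: the limit of > 100000 nM in this assay, at which 1 of the 4 values shown sits. Within the data shown here, on an aromatic carbon para to a large group, the earlier compounds showed methyl and fluoro within the scatter of each other, but propyl stands apart from both, with an at least 10-fold higher number from compound 1 to compound 4 (1.01 log units; beyond the scatter) and an at least 12-fold higher number from compound 2 to compound 4 (1.09 log units; beyond the scatter). Methoxy had given the highest number so far, yet the series also shows an at least 2.8-fold higher number from compound 3 to compound 4 (0.45 log units; beyond the scatter), so a hydrocarbon group at this position does not by itself keep the number near that of compound 1, and chain length matters here.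

Open, going by these compounds, is whether an ethyl group already gives the same rise, or whether it appears only with propyl. Also open, on these data alone, is how a branched isopropyl group, a cyclopropyl ring or a propyl chain ending in an amine would read at this position.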